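A few compounds are considered here, and "the series" means these few. Any claim that something is new, unique, unknown or untested is made for them only; others in the source may bear on it.

Measured so far: compound 1 `COc1cc(CNC(=O)/C=C/c2ccccc2OC)ccc1O`, compound 2 `COc1ccccc1/C=C/C(=O)NCc1ccc(OCc2nc(C)c(C)nc2C)c(OC)c1`.

In a functional assay on SH-SY5Y cells (Homo sapiens) for cytotoxicity, read by MTT assay, with stated times of 24 h and 4 h (a lower number here means that less compound is needed, a higher number that more compound is needed for the effect), compound 1 gives 5980 nM. In this assay, for the measured compounds named here, compound 2 gives 7150 nM, the higher of the two numbers, with compound 1 as its only neighbour: a 1.2-fold higher number from compound 1 to compound 2 (0.08 log units; within the scatter), within the scatter.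

Compound 3 `COc1cc(OC)c(OC)cc1/C=C/C(=O)NCc1ccc(OCc2nc(C)c(C)nc2C)c(OC)c1` differs from compound 2 by 2,4,5-trimethoxyphenyl in place of 2-methoxyphenyl on a double-bonded chain carbon bound to a double-bonded chain carbon. Going by the values given here, the one measured step, a 1.2-fold higher number from compound 1 to compound 2 (0.08 log units; within the scatter), alters the opposite end of the shared core and does not bear on this change; no measured pair informs it. No step beyond the scatter is therefore expected in this assay, and the range is kept wide. Compound 3 is estimated at 7000 nM, between 3000 nM and 16000 nM. The expected step is a 1.0-fold lower number from compound 2 to compound 3 (0.01 log units; within the scatter).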

Compound 3, half-maximal effective concentration: 3620 nM
For compound 3 the middle estimate is 1.9-fold (0.29 log units) above the measured one; measured number inside the range.
By their numbers in this assay, from the lowest: compounds 3, 1 and 2 (each within the scatter of the next).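

In this assay this position now has a measured step of its own: 2,4,5-trimethoxyphenyl in place of 2-methoxyphenyl gives a 2.0-fold lower number from compound 2 to compound 3 (0.30 log units; within the scatter) and so shows no change beyond the scatter. A group of 12 heavy atoms and 3 hydrogen-bond acceptors is therefore accepted here in place of one of 8 heavy atoms and 1 acceptor, with the number staying in the same range. Nothing available accounts for this result.

Still open, from the compounds shown here alone, is how a phenyl ring carrying an amine or a carboxylic acid would read at this position. Also open, going by these compounds, is whether the same exchange would give a similar step on the core of compound 1, which lacks the (3,5,6-trimethylpyrazin-2-yl)methyl group.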